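Amide Substituent Change in a Fluorophenyl Dihydrofuran Series

The source may report more compounds than this note shows. Statements on the series, on what has been measured and on what is new or still open speak of the compounds shown alone.

Measured so far:
compound 1, `C=CC1=C(C(=O)NCc2ccc(Cl)cc2)C(c2ccc(F)cc2)OC1`, 36900 nM
compound 2, `C=CC1=C(C(=O)Nc2ccccc2)C(c2ccc(F)cc2)OC1`, 46700 nM

In a functional assay on QGY7701 cells (Homo sapiens) for cytotoxicity, read by MTT assay, with a stated time of 24 h (on this read-out lower numbers stand for stronger inhibition and higher numbers for weaker inhibition), compound 2 gives the higher of the two numbers, with compound 1 the nearest neighbour; the step of a 1.3-fold higher number from compound 1 to compound 2 (0.10 log units; within the scatter) does not separate the two beyond the scatter. Compound 3, `C=CC1=C(C(=O)NC2CCCCC2)C(c2ccc(F)cc2)OC1`, carries the change cyclohexyl in place of phenyl on an amide-type nitrogen on the shared core. Among the compounds with values here, no measured step covers this particular change; the only step in hand is the one from compound 1 to compound 2, which was within the scatter, so the data give no indication of a meaningful shift in this assay in either direction for this kind of amide substituent change. Compound 3 is therefore expected to stay close to compound 2, with an estimated step of a 1.0-fold lower number from compound 2 to compound 3 (0.02 log units; within the scatter). The estimate for compound 3 in this assay is 45000 nM, expected to fall between 20000 nM and 100000 nM.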

Compound 3, half-maximal inhibitory concentration: 40500 nM
Compound 3: the middle estimate sits 1.1-fold (0.05 log units) above what was measured; measured number inside the range.
By their numbers in this assay, from the lowest: compounds 1, 3 and 2 (each within the scatter of the next).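

In this assay, a non-aromatic ring of carbon only on the amide-type nitrogen gives a result close to that of the aromatic ring it replaces: cyclohexyl in place of phenyl gives a 1.2-fold lower number from compound 2 to compound 3 (0.06 log units; within the scatter), and cyclohexyl in place of 4-chlorobenzyl gives a 1.1-fold higher number from compound 1 to compound 3 (0.04 log units; within the scatter). Compounds 1, 2 and 3 thus extend the series to an aromatic ring, a benzyl group and a saturated ring at this position, and none of the steps among them lies beyond the scatter. Nothing available explains why these numbers stay together.

The compounds shown leave open whether any substituent on this nitrogen can separate itself from these three, for example a group carrying an amine or a carboxylic acid, or a longer alkyl chain. They also leave open whether changes elsewhere on the shared core would shift the number.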